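Shortening the amine chain in a CXCR4 antagonist series

The source may report more compounds than this note shows. Statements on the series, on what has been measured and on what is new or still open speak of the compounds shown alone.

Measured so far:
compound 1 `c1cncc(CNCCCCN(C[C@H]2Cc3ccccc3CN2)[C@H]2CCCc3cccnc32)c1` – 15.3 nM
compound 2 `c1ccc(CNCCCCN(C[C@H]2Cc3ccccc3CN2)[C@H]2CCCc3cccnc32)cc1` – 20.1 nM
compound 3 `c1ccc2c(c1)CN[C@@H](CN(CCCCNC1CCOCC1)[C@H]1CCCc3cccnc31)C2` – 29.4 nM

All three were tested in a functional assay on cells for antagonist activity at C-X-C chemokine receptor type 4 (Homo sapiens), read by fluorescence and calcium flux, with stated times of 25 min and 90 s; on this read-out lower numbers stand for stronger inhibition and higher numbers for weaker inhibition. Compound 3 gives the highest of the three numbers, but the gaps to its neighbours are small: a 1.9-fold higher number from compound 1 to compound 3 (0.28 log units; within the scatter) and a 1.5-fold higher number from compound 2 to compound 3 (0.17 log units; within the scatter) both fall within the scatter, as does a 1.3-fold higher number from compound 1 to compound 2 (0.12 log units; within the scatter). On these numbers the three compounds cannot be told apart.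

Compound 4 `CC(C)(CN)CCN(C[C@H]1Cc2ccccc2CN1)[C@H]1CCCc2cccnc21` is not yet measured. Relative to compound 3 the change is 1-(aminomethyl)-1-methylethyl in place of 2-((oxan-4-yl)amino)ethyl on a saturated chain carbon, two bonds along the chain from an amine nitrogen. The measured steps only swapped the group on the distal amine nitrogen, leaving the chain itself and the position of that nitrogen untouched; each such swap stayed within the scatter. The step to compound 4 is different in kind: the chain is cut shorter, branched, and the distal nitrogen is left bare. For the measured compounds named here, no measured pair shows the effect of such a change, so the expectation rests only on the observation that the distal end has tolerated variation so far. A weakening of modest size is expected, a 1.5-fold higher number from compound 3 to compound 4 (0.18 log units; within the scatter), but with wide uncertainty in both directions. Compound 4 is therefore estimated at 45 nM, with a range from 10 nM to 200 nM.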

Compound 4, half-maximal inhibitory concentration: 69 nM
Estimate against measurement, compound 4: 1.5-fold (0.19 log units) below; the range from low to high includes it.
By their numbers in this assay, from the lowest: compounds 1, 2 and 3 (each within the scatter of the next); then compound 4.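

Until now, swapping the group on the far amine nitrogen had stayed within the scatter, but replacing the whole chain end with 1-(aminomethyl)-1-methylethyl does not in this assay, giving a 2.3-fold higher number from compound 3 to compound 4 (0.37 log units; beyond the scatter) and a 3.4-fold higher number from compound 2 to compound 4 (0.54 log units; beyond the scatter) and also a 4.5-fold higher number from compound 1 to compound 4 (0.65 log units; beyond the scatter) as its steps from the three earlier compounds. The tolerance seen so far therefore has a limit at this place, on a saturated chain carbon two bonds along the chain from an amine nitrogen, although all three steps are only modest in size and a compound with no ring at the chain end and far fewer heavy atoms there still inhibits the receptor. Nothing available here accounts for this loss.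

This single change shortens the chain, adds branching and leaves the amine bare, and the compounds shown cannot separate these three alterations. An unbranched chain ending in a bare amine, or the same 1-(aminomethyl)-1-methylethyl chain with benzyl or oxan-4-yl on its nitrogen, would show which alteration carries the loss.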